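Replacing ethyl with 4-methoxy-3,5-dimethylpyridin-2-yl in compound 2

The source may report more compounds than this note shows. Statements on the series, on what has been measured and on what is new or still open speak of the compounds shown alone.

Going by the values given here, in a functional assay on a cell-free system (plasma, Homo sapiens) for inhibition, with Plasma (Rattus norvegicus) as the target (a lower number here means a stronger inhibitor, a higher number a weaker inhibitor), compound 2 (`CCCOc1ccc2c(N3CCNCC3)cc(=O)oc2c1C`) gives 2950 nM, the higher of the two numbers so far. Among the compounds with values here, compound 1 (`Cc1c(OCc2cccnc2)ccc2c(N3CCNCC3)cc(=O)oc12`) is the only neighbour. Compound 3 (`COc1c(C)cnc(COc2ccc3c(N4CCNCC4)cc(=O)oc3c2C)c1C`), not yet measured, carries 4-methoxy-3,5-dimethylpyridin-2-yl in place of ethyl on a saturated chain carbon bound to an oxygen on an aromatic ring. Within the data shown here, one measured step bears on this change: a 3.0-fold higher number from compound 1 to compound 2 (0.48 log units; beyond the scatter), modest but beyond the scatter, with ethyl replacing pyridin-3-yl at that same place. Read in reverse, it points to a lower number with the ring, as in compound 1 at 980 nM. Among the measured compounds shown here, no measured compound carries the substituted ring, so the expectation is loose. The expected change is a 3.3-fold lower number from compound 2 to compound 3 (0.52 log units; beyond the scatter), similar in size to the measured step. The estimate for compound 3 is 900 nM, expected to fall within 300 nM to 2700 nM.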

Compound 3, half-maximal inhibitory concentration: 3300 nM
Estimate against measurement, compound 3: 3.7-fold (0.56 log units) below, outside the stated range (above it).
By their numbers in this assay, from the lowest: compound 1; then compounds 2 and 3 (each within the scatter of the next).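

In this assay, 4-methoxy-3,5-dimethylpyridin-2-yl and ethyl cannot be told apart on the saturated chain carbon bound to an oxygen on an aromatic ring, with a 1.1-fold higher number from compound 2 to compound 3 (0.05 log units; within the scatter) as the step. A six-membered aromatic ring with one hetero atom at this place is therefore not enough to give the lower number of compound 1, as a 3.4-fold higher number from compound 1 to compound 3 (0.53 log units; beyond the scatter) shows, and compound 3 goes against the reading drawn from the earlier pair alone. Nothing available explains why the two ring-bearing compounds differ.

Still open, from the compounds shown here alone, is whether the difference between the two rings follows from the point of attachment or from the methoxy and methyl groups. An unsubstituted pyridin-2-yl and a 4-methoxypyridin-2-yl at this place would separate those possibilities.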